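Swapping the Carboxyphenyl End of Compound 2

The source may report more compounds than this note shows. Statements on the series, on what has been measured and on what is new or still open speak of the compounds shown alone.

In an ADME assay on the whole organism for pharmacokinetics, with Rattus norvegicus as the target, at a dose of 2 mg/kg by the intravenous route (a lower number here means that more of the compound stays in the plasma, a higher number that more of the compound sits outside the plasma), compound 2 (`Cc1c(OCCCCOc2ccc(C(=O)O)cc2)ccc(C(=O)CC(C)C)c1O`) gives 0.81 L/kg. Compound 1 (`COc1cc(C(=O)O)ccc1OCCCCOc1ccc(C(=O)CC(C)C)c(O)c1C`) gives 0.55 L/kg, within the scatter of compound 2, while compound 3 (`COc1ccc(C(=O)O)cc1OCCCCOc1ccc(C(=O)CC(C)C)c(O)c1C`) gives 2.87 L/kg, beyond the scatter above compound 2. Compound 4 (`Cc1c(OCCCCOc2ccc(F)c(C(=O)O)c2)ccc(C(=O)CC(C)C)c1O`) carries 3-carboxy-4-fluorophenyl in place of 4-carboxyphenyl on an oxygen on a saturated carbon. For the measured compounds named here, the only measured step, a 1.5-fold higher number from compound 1 to compound 2 (0.17 log units; within the scatter), is hydrogen in place of methoxy and does not cover this change. Going by the values given here, no measured compound carries fluorine. With compound 3 at 2.87 L/kg as the only sign of wider spread, a small upward move is expected, an estimated 1.5-fold higher number from compound 2 to compound 4 (0.17 log units; within the scatter). For compound 4 the estimate is 1.2 L/kg, with an expected range from 0.55 L/kg to 2.6 L/kg.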

Compound 4, volume of distribution at steady state: 0.89 L/kg
Estimate against measurement, compound 4: 1.3-fold (0.13 log units) above; low and high end bracket the measured number.
By their numbers in this assay, from the lowest: compounds 1, 2 and 4 (each within the scatter of the next); then compound 3.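

In this assay, 3-carboxy-4-fluorophenyl in place of 4-carboxyphenyl gives a 1.1-fold higher number from compound 2 to compound 4 (0.04 log units; within the scatter), so this exchange on an oxygen on a saturated carbon leaves the read-out unresolved from that of compound 2. The earlier step covered only hydrogen in place of methoxy, whereas this one adds fluorine and relocates the carboxylic acid in a single change. No evidence on why the number holds is available. The fluorine and the relocated carboxylic acid remain inseparable here, as 3-carboxyphenyl without fluorine is absent from the compounds shown. Also open, as far as these compounds go, is how a tetrazole or a primary amide would behave in place of the carboxylic acid.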